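Benzyl in place of isopropyl on an aromatic carbon

The source may report more compounds than this note shows. Statements on the series, on what has been measured and on what is new or still open speak of the compounds shown alone.

Of the compounds shown here, two have numbers so far in a physicochemical assay for lipophilicity (on this read-out higher numbers stand for higher lipophilicity and lower numbers for lower lipophilicity), and they sit clearly apart. Compound 1 (`CC(C)c1c(O)cc2oc(-c3ccccc3)cc(=O)c2c1O`) gives 5.95 as the lower of the two. Compound 2 (`CC(C)Oc1c(C(C)C)c(O)c2c(=O)cc(-c3ccccc3)oc2c1C(C)C`) gives 6.84 and that gap lies beyond the usual scatter of repeated measurements. Among the measured compounds shown here, no two measured compounds differ in just one place, so no measured step can serve as a guide here.

Compound 3 (`O=c1cc(-c2ccccc2)oc2cc(O)c(Cc3ccccc3)c(O)c12`) has not been measured yet. It departs from compound 1 in one place, with benzyl in place of isopropyl on an aromatic carbon. That carbon is ortho to two hydroxy groups. The entering group holds more carbon and one aromatic ring, and neither group brings hydrogen-bond donors or acceptors.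

On that structural change alone, a moderate upward move is what seems likely. The expected rise in this assay is estimated as a number 0.50 log units higher from compound 1 to compound 3 (beyond the scatter) and so somewhat beyond the scatter. For compound 3 the estimated value is 6.45 with an expected range from 5.9 to 7 on this scale.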

Compound 3, partition coefficient: 6.1
For compound 3 the middle estimate is 0.35 log units above the measured one; measured number inside the range.
By their numbers in this assay, from the lowest: compounds 1 and 3 (each within the scatter of the next); then compound 2.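

In this assay, putting benzyl in place of isopropyl on this aromatic carbon, ortho to two hydroxy groups, gives a number 0.15 log units higher from compound 1 to compound 3 (within the scatter) and so leaves the two compounds indistinguishable on this read-out. Among the compounds shown here, this is the first measured step at this position, and it shows that a group of 7 heavy atoms with one six-membered aromatic ring can stand where a group of 3 heavy atoms stood without a step beyond the usual scatter. Nothing available accounts for the size of this step.

For the compounds shown here, it remains open whether an amine, a carboxylic acid or a longer chain on this same carbon would give a step beyond the scatter, since benzyl and isopropyl are the only groups compared here with the rest of the structure held the same. Going by these compounds, compound 2 differs from compound 1 in more than one place, so it says nothing about this position alone, and whether benzyl in place of isopropyl would give a similar step on another core also remains unknown.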